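Sulfonyl substituent variation in a nitrofuran carboxamide series

A few compounds are considered here, and "the series" means these few. Any claim that something is new, unique, unknown or untested is made for them only; others in the source may bear on it.

Working notes on the series. The three measured compounds share one core and differ only in the group on the sulfonyl sulfur. In an assay on CHO-K1 cells for activation of DNA damage-inducible transcript 3 protein (Homo sapiens), read by a luciferase reporter (on this read-out higher numbers stand for an effect only at larger amounts of compound and lower numbers for an effect already at smaller amounts), compound 1 `CC1CN(S(=O)(=O)c2ccc(NC(=O)c3ccc([N+](=O)[O-])o3)cc2)CC(C)O1` gives 1400 nM. Compound 2 `O=C(Nc1ccc(S(=O)(=O)N2CCNCC2)cc1)c1ccc([N+](=O)[O-])o1` gives 26400 nM in this assay, and compound 3 `CC1(C)CCN(S(=O)(=O)c2ccc(NC(=O)c3ccc([N+](=O)[O-])o3)cc2)CC1` gives 600 nM. Compound 3 stands at the lowest number of the three: the step of a 2.3-fold lower number from compound 1 to compound 3 (0.37 log units; beyond the scatter) is modest, while a 44-fold lower number from compound 2 to compound 3 (1.64 log units; beyond the scatter) is large, as is a 19-fold higher number from compound 1 to compound 2 (1.28 log units; beyond the scatter) in the other direction.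

Compound 4 `O=C(Nc1ccc(S(=O)(=O)c2ccccc2)cc1)c1ccc([N+](=O)[O-])o1` is not yet measured. The change from compound 3 is phenyl in place of 4,4-dimethylpiperidin-1-yl on a sulfonyl sulfur. All three measured steps exchange one nitrogen-linked saturated ring for another on the same sulfur; none removes the nitrogen link or introduces an aromatic ring, so they bear on compound 4 only indirectly. They show that the sulfonyl substituent can move the number over a large span, with the piperazin-1-yl group, in compound 2, at the high end and the 4,4-dimethylpiperidin-1-yl group, in compound 3, at the low end. For compound 4 a step of a 2.5-fold higher number from compound 3 to compound 4 (0.40 log units; beyond the scatter) is expected, in the direction of a higher number, with wide uncertainty. The estimate for compound 4 is 1500 nM, with a range from 300 nM to 8000 nM.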

Compound 4, concentration for half-maximal activity: 1100 nM
The estimate for compound 4 lay 1.4-fold (0.13 log units) above the measured number; the range from low to high includes it.
By their numbers in this assay, from the lowest: compounds 3, 4 and 1 (each within the scatter of the next, the first and the last beyond it); then compound 2.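

Working from these numbers, a nitrogen link on the sulfonyl sulfur is not needed for a number in the range of compound 1 and compound 3: in this assay phenyl in place of 4,4-dimethylpiperidin-1-yl gives a 1.8-fold higher number from compound 3 to compound 4 (0.26 log units; within the scatter) and phenyl in place of 2,6-dimethylmorpholin-4-yl gives a 1.3-fold lower number from compound 1 to compound 4 (0.10 log units; within the scatter) in the same read-out. Phenyl in place of piperazin-1-yl is a step of another size, a 24-fold lower number from compound 2 to compound 4 (1.38 log units; beyond the scatter) and so the aromatic ring of carbon only joins the two saturated rings of compound 1 and compound 3, while compound 2 stays alone at the high end among the four compounds. No data on hand bear on what sets piperazin-1-yl apart from the other three groups.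

Open, on these data alone, is whether the phenyl group keeps this number when it carries a substituent such as methoxy or a carboxylic acid. Also open, as far as these compounds go, is whether an acetyl group on the free ring nitrogen of piperazin-1-yl, or an open-chain group such as diethylamino on the sulfonyl sulfur, would fall with compound 2 or with the other three.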